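Swapping the triazole substituent in two lactone-derived cores

This account rests on a few compounds, and the source may have more. Where it says the series, first, only, none or still open, it means among the compounds named here.

Compound 1 `O=C1O/C(=C\Cn2cc(Cc3ccccc3)nn2)C(OCc2ccccc2)=C1OCc1ccccc1` and compound 2 `CC(C)(C)c1ccc(-c2cn(C/C=C3\OC(=O)C(OCc4ccccc4)=C3OCc3ccccc3)nn2)cc1` share one core and differ only on the triazole ring. benzyl in place of 4-(tert-butyl)phenyl on an aromatic carbon In a functional assay on MDA-MB-231 cells (Homo sapiens) for antiproliferative activity, read by MTT assay, with a stated time of 24 h (a lower number here means a stronger inhibitor, a higher number a weaker inhibitor), compound 2 gives 51200 nM, and compound 1 gives 29200 nM, so the step is a 1.8-fold lower number from compound 2 to compound 1 (0.24 log units; within the scatter). Compound 3 `CC(C)(C)c1ccc(-c2cn(CCC3(O)NC(=O)C(OCc4ccccc4)=C3OCc3ccccc3)nn2)cc1` carries a different core; how it differs from the core of compound 2 is not broken down here. In this assay compound 3 gives only a limit, > 100000 nM, which is the limit of > 100000 nM in this assay, at which 1 of the 3 values shown sits. Compound 4 `O=C1NC(O)(CCn2cc(Cc3ccccc3)nn2)C(OCc2ccccc2)=C1OCc1ccccc1` applies the same change to compound 3. benzyl in place of 4-(tert-butyl)phenyl on an aromatic carbon Compound 3 gives only a limit, so the step cannot be read directly. Judged by the measured step of a 1.8-fold lower number from compound 2 to compound 1 (0.24 log units; within the scatter), the step of a number no higher from compound 3 to compound 4 (the limit leaves the size open) is expected to stay within the scatter. Compound 4 is therefore expected to give about 100000 nM, most likely again reported as a limit.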

Compound 4, half-maximal inhibitory concentration: > 100000 nM
Compound 4 was reported as a limit (the forecaster's own chance of this, stated with the estimate: 70%); the middle value sits exactly at the limit.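

Compound 3 and compound 4 are both reported only as a limit, so the step between them cannot be read: the limit of > 100000 nM in this assay, at which 2 of the 4 values shown sit.

On these data alone, whether benzyl in place of 4-(tert-butyl)phenyl makes any difference on the core of compound 3 stays open.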